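The source may hold more compounds than are shown below. What is called first, only, known or untested is meant among the compounds shown, and "the series" means these compounds.

Compound 1 `CC(C)c1sc(-c2ccccc2)c(-c2cccc(F)c2)c1/C=C/[C@@H](O)C[C@@H](O)CC(=O)O` and compound 2 `CC(C)c1sc(-c2ccccc2)c(-c2ccc(-c3ccccc3)cc2)c1/C=C/[C@@H](O)C[C@@H](O)CC(=O)O` share the same core and differ only in the group on one aromatic carbon. In an assay on microsomes for inhibition of 3-hydroxy-3-methylglutaryl-coenzyme A reductase (Rattus norvegicus) (on this read-out higher numbers stand for weaker inhibition and lower numbers for stronger inhibition), compound 1 gives 49 nM. Compound 2 reaches only the limit of this assay, > 10000 nM, and no number. The step from compound 1 to compound 2 is therefore known only as a bound, an at least 200-fold higher number from compound 1 to compound 2 (2.30 log units; beyond the scatter), because the limit of > 10000 nM in this assay, at which 1 of the 2 values shown sits, leaves the true size of the loss open. Compound 3 `CC(C)c1sc(-c2ccccc2)c(-c2cccs2)c1/C=C/[C@@H](O)C[C@@H](O)CC(=O)O` is not yet measured; it departs from compound 2 by thiophen-2-yl in place of 4-phenylphenyl on an aromatic carbon. Going by the values given here, the single measured step bears on it in the reverse sense: the large move from compound 1 to compound 2 an at least 200-fold higher number from compound 1 to compound 2 (2.30 log units; beyond the scatter) was made by going from a small aryl group to the 4-phenylphenyl group, and compound 3 returns to a small aromatic ring. A large step downward in this assay is therefore expected from compound 2 to compound 3, an at least 100-fold lower number from compound 2 to compound 3 (2.00 log units; beyond the scatter). Compound 3 is estimated at 100 nM, with a range from 20 nM to 1000 nM.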

Compound 3, half-maximal inhibitory concentration: 1420 nM
Estimate against measurement, compound 3: 14-fold (1.15 log units) below; measured number outside the range, above it.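

In this assay, exchanging 4-phenylphenyl for thiophen-2-yl brings the read-out back from the limit to a measured number, and the step is beyond the scatter: an at least 7.0-fold lower number from compound 2 to compound 3 (0.84 log units; beyond the scatter). Going by these compounds alone, compound 2 has only a limit, so this step is a bound and its true size remains unknown because of that limit: the limit of > 10000 nM in this assay, at which 1 of the 3 values shown sits. The return is also only partial, and this is what the earlier compounds could not show: a 29-fold higher number from compound 1 to compound 3 (1.46 log units; beyond the scatter). On this aromatic carbon, then, removing 4-phenylphenyl does not by itself recover the level seen with 3-fluorophenyl, and the two smaller aromatic groups are clearly not interchangeable.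

The compounds shown leave open whether the higher number of compound 3 goes with the ring sulfur, the five-membered ring or the loss of the fluorine, for these changes arrive together in a single step. They also do not tell how a plain phenyl, a 4-fluorophenyl or a pyridin-3-yl group on this same carbon would read, and any of these would help to separate those changes.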